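Mirror-image ring carbon in a potassium channel inhibitor series

The source may hold more compounds than are shown below. What is called first, only, known or untested is meant among the compounds shown, and "the series" means these compounds.

Measured so far:
compound 1, `COc1ccc(Cl)cc1NC(=O)CN1CCN(S(=O)(=O)N2CCC(C)CC2)C[C@@H]1C`: 3500 nM
compound 2, `COc1ccc(Cl)cc1NC(=O)N1CCCN(S(=O)(=O)N2CCC(C)CC2)CC1`: 6200 nM

In an assay on HEK293 cells for inhibition of potassium channel subfamily T member 1 (Homo sapiens), read by thallium flux (on this read-out lower numbers stand for stronger inhibition and higher numbers for weaker inhibition), compound 1 gives 3500 nM and compound 2 gives 6200 nM; the gap between these two numbers lies within the scatter, so neither can be called stronger than the other. Compound 1 thus stands with the lowest number of the two, but only just.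

Compound 3 is `COc1ccc(Cl)cc1NC(=O)CN1CCN(S(=O)(=O)N2CCC(C)CC2)C[C@H]1C`. Against compound 1 the difference is the two compounds have the same atoms and bonds and differ only in configuration as drawn: 1 of 1 stereo elements differ; a stereocentre at a saturated ring carbon is drawn S in compound 1 and R in compound 3; in plain terms compound 3 is the mirror image of compound 1 at that one carbon. Going by the values given here, no pair of measured compounds shows what such an inversion does here, so the size and direction of the step are open. A modest weakening is the expected outcome, with wide uncertainty in both directions, and the step from compound 1 to compound 3 is estimated as a 1.7-fold higher number from compound 1 to compound 3 (0.23 log units; within the scatter). Compound 3 is therefore expected to give about 6000 nM in this assay, within a range from 1500 nM to 30000 nM.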

Compound 3, half-maximal inhibitory concentration: 2400 nM
For compound 3 the middle estimate is 2.5-fold (0.40 log units) above the measured one, within the range that was stated.
By their numbers in this assay, from the lowest: compounds 3, 1 and 2 (each within the scatter of the next, the first and the last beyond it).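

This pair gives the first direct view of the stereocentre at a saturated ring carbon: drawing it R rather than S gives a 1.5-fold lower number from compound 1 to compound 3 (0.16 log units; within the scatter) in this assay. The inversion therefore has no effect that can be told apart from ordinary variation between repeated measurements, and neither mirror-image form can be called the stronger inhibitor. Any real gap hidden in that variation could have only one source: the fact that compounds 1 and 3 differ only in the configuration as drawn.

As far as these compounds go, whether an ethyl or a hydroxymethyl group on this same ring carbon would separate the two mirror-image forms remains open. The compounds shown also leave open how a version of the core with no stereocentre at this carbon would compare with compound 1 and compound 3.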